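The compounds below may be only part of what the source reports. "The series", "measured", "known", "first", "only" and "open" are said of these compounds alone.

Compound 2 `O=C(CO[N+](=O)[O-])NNC(=O)c1ccc(-n2[nH]c(=O)cc2-c2ccc(Cl)cc2)cc1` gives 21.3 ug/mL in a functional assay on aorta (Rattus norvegicus, strain Wistar) for inhibition (on this read-out higher numbers stand for an effect only at larger amounts of compound and lower numbers for an effect already at smaller amounts), the highest of the two numbers measured; its nearest neighbour is compound 1 `O=C(CO[N+](=O)[O-])NNC(=O)c1ccc(-n2[nH]c(=O)cc2-c2ccccc2O)cc1`, which gives 17.8 ug/mL, a gap within the scatter. Compound 3 `O=C(CO[N+](=O)[O-])NNC(=O)c1ccc(-n2[nH]c(=O)cc2-c2ccccc2)cc1` carries hydrogen in place of chloro on an aromatic carbon. Among the compounds with values here, the only measured step at this ring, a 1.2-fold higher number from compound 1 to compound 2 (0.08 log units; within the scatter), was within the scatter, so a further change there is expected to move the number by no more than the scatter, with no direction claimed. Compound 3 is therefore expected to give about 20 ug/mL, between 10 ug/mL and 40 ug/mL, a step of a 1.1-fold lower number from compound 2 to compound 3 (0.03 log units; within the scatter).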

Compound 3, half-maximal effective concentration: 26.7 ug/mL
The estimate for compound 3 lay 1.3-fold (0.13 log units) below the measured number; the range from low to high includes it.
By their numbers in this assay, from the lowest: compounds 1, 2 and 3 (each within the scatter of the next).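

Hydrogen in place of chloro on an aromatic carbon, para to a large group, stays within the scatter in this assay, with a 1.3-fold higher number from compound 2 to compound 3 (0.10 log units; within the scatter). Hydrogen in place of hydroxy also stays within the scatter, with a 1.5-fold higher number from compound 1 to compound 3 (0.18 log units; within the scatter), so on this read-out neither chloro nor hydroxy separates from the bare phenyl ring. No measurement at hand offers an explanation for this. As far as these compounds go, whether an amine or a carboxylic acid on this ring would move the number beyond the scatter stays open. So does the effect of any change elsewhere on the shared core.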